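Half-life of compound 4 after the isopropyl swap

This account rests on a few compounds, and the source may have more. Where it says the series, first, only, none or still open, it means among the compounds named here.

Measured in an in vitro ADME assay on microsomes (Homo sapiens) for metabolic stability; a higher number here means that the compound lasts longer, a lower number that the compound disappears faster:
- compound 1 `CNC(=O)Nc1ccc(-c2nc(N3CC4CCC(C3)O4)c3cnn(C(C)C)c3n2)cc1`: 0.2 h
- compound 2 `O=C(Nc1ccc(-c2nc(N3CC4CCC(C3)O4)c3cnn(C4CCC5(CC4)OCCO5)c3n2)cc1)Nc1cccnc1`: 0.217 h
- compound 3 `O=C(Nc1ccncc1)Nc1ccc(-c2nc(N3CC4CCC(C3)O4)c3cnn(C4CCC5(CC4)OCCO5)c3n2)cc1`: 0.217 h

For the measured compounds named here, the three values lie within the scatter of one another, so compound 1 cannot be separated from the other two, and the series so far occupies one narrow band at short half-life.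

Compound 4 `CNC(=O)Nc1ccc(-c2nc(N3CC4CCC(C3)O4)c3cnn([C@H]4CC[C@@H](O)CC4)c3n2)cc1` is the next to be read. It carries 4-hydroxycyclohexyl in place of isopropyl on an aromatic nitrogen of the core of compound 1: 4-hydroxycyclohexyl in place of isopropyl on an aromatic nitrogen.

Going by the values given here, only one measured step is available, no change at the digits printed from compound 2 to compound 3 (within the scatter). That step exchanges pyridin-3-yl for pyridin-4-yl on an amide-type nitrogen, not the group on the aromatic nitrogen, so it bears on this change only indirectly. Among the compounds with values here, no measured step covers the change itself, and the data give no size for it.

The estimate therefore leans on the flat band, with compound 1 at 0.2 h and compound 3 at 0.217 h, and allows a modest upward drift in this assay. The expected step is a 1.5-fold higher number from compound 1 to compound 4 (0.18 log units; within the scatter), which would not clearly leave the scatter. Compound 4 is expected at 0.3 h, with an estimated range of 0.15 h to 0.6 h.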

Compound 4, half-life: > 0.5 h
Compound 4: a limit, no number; the forecaster's own chance of this, stated with the estimate: 5%; middle value at least 1.6-fold (0.22 log units) away from the limit.
By their numbers in this assay, from the lowest: compounds 1, 2 and 3 (each within the scatter of the next). At a limit, above all of these: compound 4.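

In this assay compound 4 reads > 0.5 h, which is a limit of the assay and not a number. For the compounds shown here, the exchange on the aromatic nitrogen gives an at least 2.5-fold higher number from compound 1 to compound 4 (0.39 log units; beyond the scatter), the first step that lies beyond the scatter, whereas the only earlier step, at the other end of the molecule, was no change at the digits printed from compound 2 to compound 3 (within the scatter). This position on the five-membered aromatic ring can therefore move the half-life out of the narrow band shared by compound 1, compound 2 and compound 3, although the size of the move is bounded on one side only: the limit of > 0.5 h in this assay, at which 1 of the 4 values shown sits.

The change brings in the six-membered ring and the hydroxyl together, and the compounds shown do not separate the two, so plain cyclohexyl on the same nitrogen of the core of compound 1 would be the comparison that divides their shares in this step. Also open, going by these compounds, is whether the step depends on the two defined stereocentres of 4-hydroxycyclohexyl, and whether a different group on the ring, such as an amine or a carboxylic acid, would give a similar reading in this assay.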